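This account rests on a few compounds, and the source may have more. Where it says the series, first, only, none or still open, it means among the compounds named here.

Measured so far in this series:
- compound 1 `COc1ccc(F)cc1N1C(=O)CSC1c1cccc(C(=O)NCCCCn2cccn2)c1` gives 50000 nM
- compound 2 `O=C(NCCCCn1cccn1)c1cccc(C2SCC(=O)N2c2ccccn2)c1` gives 50000 nM
- compound 3 `O=C(NCCCCc1ccccc1)c1cccc(C2SCC(=O)N2c2cccc(F)c2)c1` gives 10000 nM

All three numbers come from a physicochemical assay for solubility, read by turbidimetry, measured as kinetic solubility, at pH 7.4; on this read-out higher numbers stand for higher solubility and lower numbers for lower solubility. Within the data shown here, the single measured step that changes one place, no change at the digits printed from compound 1 to compound 2 (within the scatter), replaces the whole aryl group on the amide-type nitrogen in a ring and leaves the read-out where it was. Compound 3 stands lowest of the three in this assay; compound 1 and compound 2 each sit higher by a margin beyond the scatter, and the two of them are within the scatter of each other, so no order between them is claimed.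

Compound 4 `Cc1cccc(N2C(=O)CSC2c2cccc(C(=O)NCCCCc3ccccc3)c2)c1` is the next member to be measured. It differs from compound 3 in one place, (methyl in place of fluoro on an aromatic carbon). Among the measured compounds shown here, no measured step bears on a change of this kind: the only step known concerns a different position and a different group, and it was flat. Nothing in the data therefore points in either direction for this assay, and the working expectation is a step of no size beyond the scatter, a 1.1-fold lower number from compound 3 to compound 4 (0.05 log units; within the scatter). Compound 4 is expected to come out near 9000 nM, with a range of 3000 nM to 27000 nM in this assay.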

Compound 4, solubility: 10000 nM
Compound 4: the middle estimate sits 1.1-fold (0.05 log units) below what was measured; the range from low to high includes it.
By their numbers in this assay, from the lowest: compounds 3 and 4 (each within the scatter of the next); then compounds 1 and 2 (each within the scatter of the next).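

Methyl in place of fluoro on an aromatic carbon, which turns 3-fluorophenyl into 3-methylphenyl, reads in this assay as no change at the digits printed from compound 3 to compound 4 (within the scatter) and thus gives the first reading of a swap of one heavy atom at this position. Alongside no change at the digits printed from compound 1 to compound 2 (within the scatter), where the whole aryl group changes, it leaves both steps measured so far in this series without a shift beyond the scatter, although the two steps involve different aryl groups and different chains on the amide. Nothing on hand accounts for why this exchange leaves the reading in place.

Going by these compounds, whether this assay stays as flat at this position with a group of another kind, such as an amine or a carboxylic acid, remains open, and the same holds for other places on that aromatic ring. Also open, on these data alone, is whether the flat reading from fluoro to methyl carries over to the aryl groups of compound 1 and compound 2, or to a shorter chain on the amide.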